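The compounds below may be only part of what the source reports. "The series", "measured", "known", "first", "only" and "open" are said of these compounds alone.

Measured compounds:
Compound 1 `CCC(C)C(NC(=O)n1nnc2ccccc21)C(=O)NC1CCCCC1` gives > 100000 nM in a functional assay on WI-38 cells (Homo sapiens) for inhibition; a lower number here means a stronger inhibitor, a higher number a weaker inhibitor.
Compound 2 `CC(C)C(NC(=O)NO)C(=O)NC1CCCCC1` gives 58800 nM in this assay.

The value for compound 1 in this assay is a limit of the assay rather than a number, so compound 1 can only be placed at the weak end of what the assay reports (the limit of > 100000 nM in this assay, at which 1 of the 2 values shown sits). Within the data shown here, compound 2 has a measured number, but as no step between compound 1 and compound 2 is worked out, the two values say only that compound 1 sits at the limit and compound 2 sits within the measured range; compound 2 is not a single-point neighbour of compound 1.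

Compound 3 `CCC(C)C(NC(=O)n1nnc2ccccc21)C(=O)NC1CCCC1` is the next compound of interest. It differs from compound 1 in one place: cyclopentyl in place of cyclohexyl on an amide-type nitrogen. Cyclohexyl leaves and cyclopentyl enters on the amide-type nitrogen whose other neighbour is the carbonyl carbon; the shared core is otherwise untouched. Nothing measured here tells how this exchange plays out, so the expected step that the limit leaves unreadable from compound 1 to compound 3 is small, likely none beyond the scatter, since compound 1 itself gives only the limit > 100000 nM. Compound 3 is therefore expected to give about 120000 nM, between 40000 nM and 400000 nM, most probably reported again as a limit.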

Compound 3, half-maximal inhibitory concentration: > 100000 nM
Compound 3: only a limit was reported (the forecaster's own chance of this, stated with the estimate: 70%); the middle value lies beyond the limit too.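

Compound 1 and compound 3 both stand at a limit of the assay rather than at a number, so no step can be read for cyclopentyl in place of cyclohexyl on the amide-type nitrogen: the limit of > 100000 nM in this assay, at which 2 of the 3 values shown sit.

The compounds shown leave open how far either compound lies past that limit, and whether this exchange changes inhibition at all.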